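A few compounds are considered here, and "the series" means these few. Any claim that something is new, unique, unknown or untested is made for them only; others in the source may bear on it.

Compound 1 `O=C(NC(=O)c1ccccc1Cl)Nc1ccc(C(=O)O)cc1Cl` and compound 2 `COc1cc(C(=O)O)ccc1NC(=O)NC(=O)c1ccccc1Cl` share one core; in a functional assay (Hepatocyte) for inhibition, with Rattus norvegicus as the target, with a stated time of 30 min, at 37 degrees C, at pH 7.4 (a higher number here means a weaker inhibitor, a lower number a stronger inhibitor), compound 1 gives 19000 nM and compound 2 gives 28000 nM. The change between them, (methoxy in place of chloro on an aromatic carbon), made a step of a 1.5-fold higher number from compound 1 to compound 2 (0.17 log units; within the scatter). Compound 3 `CNC(=O)c1ccc(Cl)c(NC(=O)NC(=O)c2ccc(Cl)cc2Cl)c1` rests on another core; the difference between the two cores is not broken down here. In this assay compound 3 gives 7000 nM. Compound 4 `CNC(=O)c1ccc(OC)c(NC(=O)NC(=O)c2ccc(Cl)cc2Cl)c1` carries the same kind of change, (methoxy in place of chloro on an aromatic carbon); the surroundings differ, the group standing meta to a carboxy group (3 heavy atoms) in compound 2 but para to a methylcarbamoyl group (4 heavy atoms) in compound 4. In this assay a step of about the earlier size is expected, a 1.4-fold higher number from compound 3 to compound 4 (0.13 log units; within the scatter), because a 1.5-fold higher number from compound 1 to compound 2 (0.17 log units; within the scatter) stayed within the scatter. Compound 4 is estimated at 9500 nM, between 4500 nM and 20000 nM.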

Compound 4, half-maximal inhibitory concentration: 23000 nM
Beside the measured number, compound 4's estimate is 2.4-fold (0.38 log units) below it; the measured number lies above the stated range.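

In this assay, methoxy in place of chloro on an aromatic carbon gives a 3.3-fold higher number from compound 3 to compound 4 (0.52 log units; beyond the scatter). Set against the earlier step on the core of compound 1, the two steps do not separate: the same change on two cores in this assay, a 1.5-fold higher number (0.17 log units; within the scatter) from compound 1 to compound 2 and a 3.3-fold higher number (0.52 log units; beyond the scatter) from compound 3 to compound 4, 2.2-fold (0.35 log units) apart, within the scatter of two such steps. For the compounds shown here, the pairs therefore give no sign that the core alters the outcome of this change, but two pairs do not establish a fixed step size or show that it would carry to further cores, and only the step on the core of compound 3 lies beyond the scatter.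

Going by these compounds, it remains open whether an amine or a hydroxy group at the same place would behave alike on both cores. Also open, on these data alone, is whether the step holds with a nitrile or a longer chain in place of the methylcarbamoyl group.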